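The compounds below may be only part of what the source reports. "The series", "measured", "known", "first", "only" and "open" are said of these compounds alone.

Working notes on the series.

Of the compounds shown here, two have been measured. Compound 1, `CC(C)Cc1ccc(C(C)c2nnc3sc(-c4ccc(N)cc4)nn23)cc1`, gives 37.3% in a functional assay on the whole organism (Tail, strain Swiss albino) with Mus musculus as the target, with a stated time of 4 h, at a dose of 70 mg/kg by the oral route; on this read-out lower numbers stand for less inhibition and higher numbers for more inhibition at the one dose given (going by the name of the read-out). Among the compounds with values here, compound 2, `CCCCNc1nn2c(C(C)c3ccc(CC(C)C)cc3)nnc2s1`, gives 51.4% in the same assay, and on the two numbers so far it stands highest, with compound 1 the only other point and a number 14.1 percentage points higher from compound 1 to compound 2 (beyond the scatter) separating them.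

The next compound, compound 3, `CC(C)Cc1ccc(C(C)c2nnc3sc(Nc4ccccc4)nn23)cc1`, keeps the shared core of compound 2 and is changed at one place only: phenyl in place of butyl on a nitrogen on an aromatic ring. Within the data shown here, no measured step concerns a change on this nitrogen. Among the measured compounds shown here, the one step known, from compound 1 to compound 2, exchanged the group on the aromatic carbon, so it bears on the present change only loosely; it does show that swapping an aryl-bearing group for an alkyl-bearing one moved the read-out by a modest amount. Taking that as the only guide, the expectation for compound 3 in this assay is a step of a number 7.4 percentage points lower from compound 2 to compound 3 (within the scatter), that is no change beyond the usual scatter. The estimated value for compound 3 is therefore 44%, within a range from 28% to 60%.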

Compound 3, a percentage reported as inhibition, in the whole organism at one dose (the size of the read-out at that dose, not a potency): 38.3%
Compound 3: middle estimate off by 5.7 percentage points, on the high side; low and high end bracket the measured number.
By their numbers in this assay, from the lowest: compounds 1 and 3 (each within the scatter of the next); then compound 2.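

In this assay, the nitrogen on an aromatic ring now has a measured step of its own: a number 13.1 percentage points lower from compound 2 to compound 3 (beyond the scatter), so the read-out does not hold at the level of compound 2 when phenyl takes the place of butyl on this nitrogen. Anilino in place of 4-aminophenyl on an aromatic carbon gives a number 1 percentage points higher from compound 1 to compound 3 (within the scatter), so these two aryl-bearing groups do not separate in this assay, and of the three compounds only compound 2, with its butylamino group, stands apart from the other two. No data at hand bear on the cause of either step.

Still open, on these data alone, is whether the higher number of compound 2 belongs to the butyl chain in particular or to open alkyl chains on this nitrogen in general, which an ethyl or hexyl chain, or a cyclohexyl ring, at the same place would help to settle. Also open, as far as these compounds go, is whether a group added to the phenyl of the anilino, such as a methoxy group or a carboxylic acid, would move the read-out away from the level of compound 3.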